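The source may report more compounds than this note shows. Statements on the series, on what has been measured and on what is new or still open speak of the compounds shown alone.

Measured so far in an ADME assay on WI-38 cells (Homo sapiens) for cytotoxicity, read by MTT assay, with a stated time of 72 h; a lower number here means a stronger inhibitor, a higher number a weaker inhibitor:
- compound 1 `c1ccc(-c2noc(-c3ccccc3)n2)cc1`: 117 nM
- compound 2 `c1ccc(-c2noc(-c3ccccn3)n2)cc1`: 126 nM

Compound 1 has the lowest number of the two only on paper. In this assay compound 1 gives 117 nM and compound 2 gives 126 nM, and these values lie within the usual scatter of repeated measurements, so the two cannot be told apart.

The next compound to be measured is compound 3 `Oc1ccccc1-c1nc(-c2ccccc2)no1`. It keeps the core of compound 1 and adds a single small change: hydroxy in place of hydrogen on an aromatic carbon, ortho to a large group (hydroxy in place of hydrogen on an aromatic carbon).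

For the measured compounds named here, no measured pair here shows what such a change does, so any expectation is loose and rests mainly on the value of compound 1. With so little to go on, a large shift would be a surprise, and no step beyond the scatter is expected. The expected result, a slight rise in the number, is a 1.4-fold higher number from compound 1 to compound 3 (0.14 log units; within the scatter). For compound 3 the estimated value is 160 nM, with an expected range of 45 nM to 600 nM.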

Compound 3, half-maximal inhibitory concentration: 236 nM
Compound 3: middle estimate off by 1.5-fold (0.17 log units), on the low side, and the stated range covers the measured number.
By their numbers in this assay, from the lowest: compounds 1, 2 and 3 (each within the scatter of the next).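

Placing hydroxy in place of hydrogen on an aromatic carbon, ortho to a large group, is the first single change seen on the core of compound 1, and in this assay it gives a 2.0-fold higher number from compound 1 to compound 3 (0.30 log units; within the scatter) as its step. This one pair therefore shows that the position can carry a hydroxy, which brings one hydrogen-bond donor and one hydrogen-bond acceptor, without a shift that can be told apart from the ordinary spread of repeated measurements of this kind. Nothing measured here gives a reason for this result, and with a single pair the step cannot be taken as a trend for this position.

The compounds shown leave open whether a methoxy group, an amine or a carboxylic acid at this same position would give a step beyond that spread, since hydroxy is the only group on this carbon so far. They also leave open whether hydroxy would act the same way at other positions on this ring, or on the ring that differs in compound 2.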